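This account rests on a few compounds, and the source may have more. Where it says the series, first, only, none or still open, it means among the compounds named here.

Working notes on the series. Compound 1 `COc1cc(C)cc(-c2nn(CC#N)cc2-c2ccc(-c3cccc(C(C)=O)c3)nc2)c1`, compound 2 `Cc1cc(O)cc(-c2nn(CC#N)cc2-c2ccnc(-c3ccc(Oc4ccccc4)cc3)c2)c1` and compound 3 `COc1cc(C)cc(-c2nn(CC#N)cc2-c2ccnc(-c3ccc(N(C)C)cc3)c2)c1` share a core and have all been run in a functional assay on HT-29 cells (Homo sapiens) for cytotoxicity, read by sulforhodamine B assay, with a stated time of 48 h, tested at 0.001 uM; a lower number here means a stronger effect, a higher number a weaker effect of the compound at the concentration tested. In this assay compound 1 gives 95%. Where compound 3 has a methoxy, compound 2 carries a hydroxy; in this assay compound 2 gives 95%. Compound 3 gives 103% in this assay; the numbers of compound 1 and of compound 2 differ from it by amounts within the usual scatter, so the three read as one level and none of them can be set apart from the others on these data.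

Compound 4 `Cc1cc(O)cc(-c2nn(CC#N)cc2-c2ccnc(-c3ccc(N(C)C)cc3)c2)c1` has not been run in this assay. It differs from compound 3 by hydrogen in place of methyl on an oxygen on an aromatic ring. Among the compounds with values here, no step between measured compounds has been worked out for this change, so its size is not known from the series itself; the one pointer is compound 2, which already carries the hydroxy and gives 95% in this assay, on the same level as the rest. The step expected in this assay is none beyond the scatter, in no particular direction. For compound 4 the estimate in this assay is 98%, expected to fall between 88% and 108%. The step of a number 5 percentage points lower from compound 3 to compound 4 (within the scatter) is expected to stay within the scatter.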

Compound 4, a percentage reported as activity, at one concentration (the size of the read-out at that concentration, not a potency): 101%
The estimate for compound 4 lay 3 percentage points below the measured number; low and high end bracket the measured number.
By their numbers in this assay, from the lowest: compounds 1, 2, 4 and 3 (each within the scatter of the next).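

In this assay, methoxy to hydroxy on the 3-methoxy-5-methylphenyl group now has a measured step of its own, a number 2 percentage points lower from compound 3 to compound 4 (within the scatter), so at this concentration the read-out does not separate the two groups at this position. With the hydroxy held fixed, dimethylamino in place of phenoxy on an aromatic carbon gives a number 6 percentage points higher from compound 2 to compound 4 (within the scatter), so a second place on the shared core also shows no change beyond the scatter, and the two steps together leave all four compounds on one level. Nothing available bears on why these read-outs stay level.

Since every compound sits near the same level at a single low concentration, these flat steps cannot show whether either change would matter at concentrations where the read-out moves. On these data alone, it also remains open whether a longer chain on that oxygen, such as ethoxy, or an amine in place of the hydroxy would shift the read-out in this assay beyond the scatter.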